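A few compounds are considered here, and "the series" means these few. Any claim that something is new, unique, unknown or untested is made for them only; others in the source may bear on it.

Measured so far: compound 1 `CC(Cl)C(=O)Nc1cccc(-c2nc3ccccc3s2)c1` with 769 10^-6 cm/s in an ADME assay for permeability, using PAMPA (a higher number here means that the compound crosses the layer faster, a lower number that the compound crosses the layer more slowly), and compound 2 `CC(C)(CCl)C(=O)Nc1cccc(-c2nc3ccccc3s2)c1` with 891 10^-6 cm/s in this assay.

Compound 2 stands highest of the two numbers, and its nearest neighbour is compound 1, the step of a 1.2-fold higher number from compound 1 to compound 2 (0.06 log units; within the scatter) lying within the scatter. Compound 3 `O=C(Nc1cccc(-c2nc3ccccc3s2)c1)c1cccnc1Cl` has not yet been measured in this assay. It differs from compound 2 in one place: 2-chloropyridin-3-yl in place of 1-(chloromethyl)-1-methylethyl on a carbonyl carbon. Going by the values given here, only one measured step bears on this change, a 1.2-fold higher number from compound 1 to compound 2 (0.06 log units; within the scatter), which also exchanged the group on the carbonyl carbon and left the number essentially where it was. That step swapped one open chain for another, whereas here a ring enters, so the comparison is loose. No step beyond the scatter is therefore expected for compound 3, and its number is estimated as a 1.3-fold lower number from compound 2 to compound 3 (0.10 log units; within the scatter). The expected value for compound 3 in this assay is 700 10^-6 cm/s, with a range from 350 10^-6 cm/s to 1400 10^-6 cm/s.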

Compound 3, apparent permeability: 677 10^-6 cm/s
Compound 3: middle estimate off by 1.0-fold (0.01 log units), on the high side; measured number inside the range.
By their numbers in this assay, from the lowest: compounds 3, 1 and 2 (each within the scatter of the next).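

The earlier compounds had shown only one open chain exchanged for another on this carbonyl carbon, whereas here a six-membered aromatic ring with 1 hetero atom and 1 hydrogen-bond acceptor enters at the same place. In this assay, putting 2-chloropyridin-3-yl in place of 1-(chloromethyl)-1-methylethyl gives a 1.3-fold lower number from compound 2 to compound 3 (0.12 log units; within the scatter), and putting it in place of 1-chloroethyl gives a 1.1-fold lower number from compound 1 to compound 3 (0.06 log units; within the scatter). Among these three compounds, then, the read-out does not separate a ring from an open chain at this position, and nothing at hand accounts for that.

The compounds shown leave open whether a group bearing an amine or a carboxylic acid on this carbonyl carbon would stay within the scatter of these three. On these data alone, all three groups carry chlorine, so it also remains open how a plain phenyl ring or an unchlorinated longer chain would compare.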